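From a dichlorophenyl to a chloropyridinyl sulfonyl group

The compounds below may be only part of what the source reports. "The series", "measured", "known", "first", "only" and "open" are said of these compounds alone.

Measured so far in a physicochemical assay for lipophilicity, at pH 7.4; a lower number here means a more polar compound, a higher number a more lipophilic compound:
compound 1 `N#Cc1ccc(O[C@H]2CN(S(=O)(=O)c3ccc(Cl)cc3Cl)C[C@]2(O)CO)cc1F` gives 4.9
compound 2 `N#Cc1ccc(O[C@H]2CN(S(=O)(=O)c3ccc(Cl)cc3)C[C@@]2(O)CO)cc1F` gives 4.1
compound 3 `N#Cc1ccc(S(=O)(=O)[C@H]2CN(S(=O)(=O)c3ccc(Cl)cc3Cl)C[C@@]2(O)CO)cc1` gives 4.5

Compound 1 stands highest of these three, and the other two both lie lower by more than the usual scatter of repeat measurements. Compound 3 is the nearer of the two and compound 2 the further.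

Compound 4 `N#Cc1ccc(O[C@H]2CN(S(=O)(=O)c3ccc(Cl)cn3)C[C@]2(O)CO)cc1F` has not been measured yet. It carries 5-chloropyridin-2-yl in place of 2,4-dichlorophenyl on a sulfonyl sulfur and otherwise matches compound 1. Within the data shown here, no two measured compounds differ in one place only, so no measured step sizes this change directly, and the expectation is a matter of judgement. A fall in this assay clearly beyond the scatter is expected, and compound 2 at 4.1 shows that a reading far under that of compound 1 does occur among these compounds. The estimated move is a number 1.20 log units lower from compound 1 to compound 4 (beyond the scatter) and only a measurement can confirm it. For compound 4 the expected value is 3.7 with an estimated range from 3.2 to 4.2 on this reasoning.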

Compound 4, distribution coefficient: 3.5
Beside the measured number, compound 4's estimate is 0.20 log units above it; measured number inside the range.
By their numbers in this assay, from the lowest: compound 4; then compound 2; then compound 3; then compound 1.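

In this assay, among these compounds, putting 5-chloropyridin-2-yl in place of 2,4-dichlorophenyl on a sulfonyl sulfur gives a number 1.40 log units lower from compound 1 to compound 4 (beyond the scatter), the first step here in which only one place changes. It shows that the group on this sulfonyl sulfur can by itself shift the read-out by a large amount, with the rest of compound 1 left untouched. The change removes chlorine and brings a nitrogen into the aromatic ring in a single move, and no measured evidence is available to explain the size of the step.

The compounds shown do not separate the effect of the ring nitrogen from that of the lost chlorine, which a pair carrying plain pyridin-2-yl or an amine on the ring could begin to address. From the compounds shown here alone, whether the same exchange gives a similar step on the core of compound 3 also stays open.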